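The source may hold more compounds than are shown below. What is called first, only, known or untested is meant among the compounds shown, and "the series" means these compounds.

Measured so far in a functional assay on HCT-116 cells (Homo sapiens) for antiproliferative activity, read by MTT assay, with a stated time of 72 h; on this read-out higher numbers stand for weaker inhibition and lower numbers for stronger inhibition:
- compound 1 `O=C(CSc1nc2ccccc2[nH]1)Nc1ccc2nc(NC(=O)c3ccc(C(F)(F)F)cc3)sc2c1` gives 3760 nM
- compound 2 `O=C(CSc1ncccn1)Nc1ccc2nc(NC(=O)c3ccc(C(F)(F)F)cc3)sc2c1` gives 2220 nM
- compound 3 `O=C(CSc1ccc2ccccc2c1)Nc1ccc2nc(NC(=O)c3ccc(C(F)(F)F)cc3)sc2c1` gives 300 nM

Compound 3 has the lowest number of the three. Both steps reaching it lie beyond the scatter, the large 13-fold lower number from compound 1 to compound 3 (1.10 log units; beyond the scatter) and the modest 7.4-fold lower number from compound 2 to compound 3 (0.87 log units; beyond the scatter).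

The next compound is compound 4 `O=C(CSC1CCCCC1)Nc1ccc2nc(NC(=O)c3ccc(C(F)(F)F)cc3)sc2c1`, with cyclohexyl in place of naphthalen-2-yl on a sulfur. For the measured compounds named here, no measured step covers this exchange directly, so the evidence is indirect. The step of a 1.7-fold lower number from compound 1 to compound 2 (0.23 log units; within the scatter) lies within the scatter and gives the two heteroaromatic groups no order. Only compound 3, at 300 nM, carries a group of carbon only, and cyclohexyl is also of carbon only. A return to the level of compound 2, at 2220 nM, therefore seems less likely than a smaller change. However, with only one such group measured, retention of the value of compound 3 cannot be assumed either. The expected change is a 2.7-fold higher number from compound 3 to compound 4 (0.43 log units; beyond the scatter), a modest rise in the number, though the estimate is uncertain. For compound 4 the estimated value is 800 nM, with an expected range of 250 nM to 2600 nM.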

Compound 4, half-maximal inhibitory concentration: 21000 nM
Beside the measured number, compound 4's estimate is 26-fold (1.42 log units) below it; the whole stated range lies below it.
By their numbers in this assay, from the lowest: compound 3; then compounds 2 and 1 (each within the scatter of the next); then compound 4.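

The saturated ring on the sulfur costs far more than any step among the aromatic groups, with a 70-fold higher number from compound 3 to compound 4 (1.85 log units; beyond the scatter), and it also falls behind both heteroaromatic groups, with a 9.5-fold higher number from compound 2 to compound 4 (0.98 log units; beyond the scatter) and a 5.6-fold higher number from compound 1 to compound 4 (0.75 log units; beyond the scatter). Being of carbon only is therefore not enough to hold a low number in this assay: compound 3 and compound 4 both carry groups of carbon only, yet they stand at the two ends of the series, and in these four compounds all three aromatic groups give lower numbers than cyclohexyl, with no compound going against this. Nothing available accounts for the size of this loss.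

Compound 4 differs from compound 3 both in losing the aromatic rings and in its smaller count of heavy atoms, so these two changes cannot be told apart here. On these data alone, a phenyl group and a decahydronaphthalen-2-yl group on the sulfur would separate them, while the response to an open chain such as n-hexyl or to an amine on the cyclohexyl ring remains open.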